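The source may report more compounds than this note shows. Statements on the series, on what has been measured and on what is new or still open speak of the compounds shown alone.

Of the compounds shown here, two of a shared core have been measured. Compound 1 `Cc1cccc(/C=C2\CCC/C(=C\c3ccccc3)C2=O)c1` gives 47.9% in an assay on isolated protein for inhibition of Alpha glucosidase (Homo sapiens), with stated times of 5 min and 15 min, tested at 50 uM (a lower number here means less inhibition, a higher number more inhibition at the concentration tested (going by the name of the read-out)), and compound 2 `COc1ccc(/C=C2\CCC/C(=C\c3ccccc3)C2=O)cc1` gives 31.4% in this assay. Compound 1 stands highest of the two, and the gap to compound 2 lies beyond the scatter. Compound 3 `O=C1/C(=C/c2ccccc2)CCC/C1=C\c1ccccc1F` has not yet been measured. It differs from compound 1 in one place: 2-fluorophenyl in place of 3-methylphenyl on a double-bonded chain carbon bound to a double-bonded ring carbon. For the measured compounds named here, no step between measured compounds is known that would show how this change acts, since compound 2 differs from compound 1 at another group. The account therefore works from compound 1 alone. Compound 3 is expected to land somewhat lower than compound 1, a step of a number 7.9 percentage points lower from compound 1 to compound 3 (within the scatter) that may or may not exceed the scatter. For compound 3 the estimate in this assay is 40%, with a range from 25% to 55%.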

Compound 3, a percentage reported as inhibition, at one concentration (the size of the read-out at that concentration, not a potency): 43%
For compound 3 the middle estimate is 3 percentage points below the measured one; the range from low to high includes it.
By their numbers in this assay, from the lowest: compound 2; then compounds 3 and 1 (each within the scatter of the next).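

In this assay, for the compounds shown here, the exchange of 3-methylphenyl for 2-fluorophenyl on a double-bonded chain carbon bound to a double-bonded ring carbon gives a number 4.9 percentage points lower from compound 1 to compound 3 (within the scatter) and is the only step on hand that isolates a change at this place. It shows that this place accepts this exchange of one substituted phenyl group for another with no change that can be told from the scatter. No measurement on hand speaks to why these two groups read alike.

As far as these compounds go, whether a phenyl group carrying an amine or a carboxylic acid would read the same at this place remains open. So does whether the same exchange would read alike with a group other than the unsubstituted phenyl at the other end of the shared core.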